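Swapping bromo for chloro in compound 3

This account rests on a few compounds, and the source may have more. Where it says the series, first, only, none or still open, it means among the compounds named here.

Values so far in a functional assay on K562 cells (Homo sapiens) for antiproliferative activity, read by sulforhodamine B assay, with a stated time of 48 h (a lower number here means a stronger inhibitor, a higher number a weaker inhibitor), are these
- Compound 1 `O=C1NCCN1c1ccc(S(=O)(=O)Nc2ccc3[nH]ccc3c2)cc1` gives 340 nM
- Compound 2 `COc1cc(NS(=O)(=O)c2ccc(N3CCNC3=O)cc2)cc(OC)c1OC` gives 19 nM
- Compound 3 `O=C1NCCN1c1ccc(S(=O)(=O)Nc2cccc(Br)c2)cc1` gives 87 nM

Compound 3 stands in the middle of these three numbers. Compound 1 has the higher number and compound 2 the lower, and both gaps lie beyond the scatter.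

Compound 4 `O=C1NCCN1c1ccc(S(=O)(=O)Nc2cccc(Cl)c2)cc1` has not been measured yet. The change chloro in place of bromo on an aromatic carbon puts chloro in place of bromo on an aromatic carbon, so 3-bromophenyl becomes 3-chlorophenyl. Among the measured compounds shown here, no measured pair shows this swap, so the starting point is compound 3 at 87 nM and nothing more. Expected here is a 1.1-fold higher number from compound 3 to compound 4 (0.06 log units; within the scatter) in this assay which would stay within the scatter, with no firm direction. For compound 4 the estimated value is 100 nM with an expected range from 45 nM to 220 nM once tested.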

Compound 4, half-maximal inhibitory concentration: 69 nM
Estimate against measurement, compound 4: 1.4-fold (0.16 log units) above; measured number inside the range.
By their numbers in this assay, from the lowest: compound 2; then compounds 4 and 3 (each within the scatter of the next); then compound 1.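

In this assay, putting chloro in place of bromo gives a 1.3-fold lower number from compound 3 to compound 4 (0.10 log units; within the scatter), so this assay does not separate the two halogens at this position on the phenyl ring. Compounds 3 and 4 are the only pair shown that differ in one place, and this swap leaves the number within the scatter. No supporting evidence bears on this result. The compounds shown leave open how fluoro, a carboxylic acid or an amine would compare at this same position. They also leave open whether chloro and bromo would still match on another part of the ring.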